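Swapping a Bromophenyl for a Nitrophenyl Group

A few compounds are considered here, and "the series" means these few. Any claim that something is new, unique, unknown or untested is made for them only; others in the source may bear on it.

Compound 2 `Brc1ccc(CSc2nnc(-c3ccncc3)n2-c2ccccc2)cc1` carries a 4-bromophenyl group on a saturated chain carbon bound to a sulfur, and in a functional assay on MCF7 cells (Homo sapiens) for inhibition, read by MTT assay, with a stated time of 48 h (on this read-out lower numbers stand for stronger inhibition and higher numbers for weaker inhibition), compound 2 gives 12600 nM. Compound 1 `Clc1ccccc1CSc1nnc(-c2ccncc2)n1-c1ccccc1` gives 18100 nM in this assay; the step of a 1.4-fold lower number from compound 1 to compound 2 (0.16 log units; within the scatter) shows that compound 2 holds the lower of the two numbers without standing apart from compound 1. Compound 3 `O=[N+]([O-])c1ccccc1CSc1nnc(-c2ccncc2)n1-c1ccccc1` differs from compound 2 by 2-nitrophenyl in place of 4-bromophenyl on a saturated chain carbon bound to a sulfur. Going by the values given here, because a 1.4-fold lower number from compound 1 to compound 2 (0.16 log units; within the scatter) stayed within the scatter for the only change measured at this place, the change is expected to bring a 1.1-fold higher number from compound 2 to compound 3 (0.05 log units; within the scatter). Compound 3 is therefore estimated at 14000 nM, within 6000 nM to 35000 nM.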

Compound 3, half-maximal inhibitory concentration: > 50000 nM
Compound 3 gave a limit, no number (the forecaster's own chance of this, stated with the estimate: 5%); at least 3.5-fold (0.55 log units) between middle value and limit.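

Going by these compounds alone, until now, no change at this place on a saturated chain carbon bound to a sulfur had moved the result in this assay beyond the scatter, so 2-nitrophenyl is the first group here to do so, giving weaker inhibition. The swap for 4-bromophenyl gives an at least 3.9-fold higher number from compound 2 to compound 3 (0.59 log units; beyond the scatter), and nitro in place of chloro on an aromatic carbon gives an at least 2.7-fold higher number from compound 1 to compound 3 (0.44 log units; beyond the scatter). Compound 3 has only a limit and no number, so the full size of both steps stays unknown: the limit of > 50000 nM in this assay, at which 1 of the 3 values shown sits.

Still open, as far as these compounds go, is how a phenyl ring carrying an amine or a carboxylic acid would read at this place.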